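The source may hold more compounds than are shown below. What is called first, only, known or untested is meant among the compounds shown, and "the series" means these compounds.

Two pairs, each on its own core. Compound 1 `COc1ccc(N(C)c2nc(NC3CCCC3)c3ccccc3n2)cc1` and compound 2 `COc1ccc(N(C)c2nc(NCCCO)c3ccccc3n2)cc1` share the core of compound 1; compound 3 `N#Cc1ccc(Nc2nc(NC3CCCC3)c3ccccc3n2)cc1` and the unmeasured compound 4 `N#Cc1ccc(Nc2nc(NCCCO)c3ccccc3n2)cc1` share the core of compound 3. The difference between the two cores is not broken down here.

In a functional assay on KB cells (Homo sapiens) for antiproliferative activity, read by sulforhodamine B assay, with a stated time of 48 h (on this read-out higher numbers stand for weaker inhibition of growth and lower numbers for stronger inhibition of growth), compound 1 gives 11700 nM. In this assay compound 2 gives 24800 nM. The change between them is 3-hydroxypropyl in place of cyclopentyl on a nitrogen on an aromatic ring, and it made a step of a 2.1-fold higher number from compound 1 to compound 2 (0.33 log units; beyond the scatter). For compound 3 the read-out of this assay is only a limit, > 31300 nM, not a number.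

The same change is made again from compound 3 to compound 4: 3-hydroxypropyl in place of cyclopentyl on a nitrogen on an aromatic ring. Compound 3 already sits at the limit of > 31300 nM in this assay, at which 1 of the 3 values shown sits, so a step of the size seen on the core of compound 1 would carry compound 4 further past that edge, and a second limit rather than a number is expected. Compound 4 is estimated at 60000 nM, with a range of 25000 nM to 150000 nM. The expected step is a step that the limit leaves unreadable from compound 3 to compound 4.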

Compound 4, concentration for 50% growth inhibition: 23700 nM
For compound 4 the middle estimate is 2.5-fold (0.40 log units) above the measured one; measured number outside the range, below it.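

Carried to the second core, 3-hydroxypropyl in place of cyclopentyl gives, in this assay, an at least 1.3-fold lower number from compound 3 to compound 4 (0.12 log units; that floor lies within the scatter). The change therefore does not carry over as a fixed step between these two cores: the same change on two cores in this assay, a 2.1-fold higher number (0.33 log units; beyond the scatter) from compound 1 to compound 2 and an at least 1.3-fold lower number (0.12 log units; that floor lies within the scatter) from compound 3 to compound 4, at least 2.7-fold (0.44 log units) apart, beyond the scatter of two such steps. Compound 3 has only a limit, > 31300 nM, so the size of this step remains a floor, and a single pair on each core gives neither a rule for further cores nor a reason for the gap.

Going by these compounds, it remains open whether a longer chain ending in a hydroxyl, or a chain ending in an amine or a carboxylic acid, would follow the step on the core of compound 1 or the one on the core of compound 3. The compounds shown also do not separate which part of the difference between the two cores goes with the gap between the steps.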